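Acetamide in place of urea on a dioxane-fused core

The source may hold more compounds than are shown below. What is called first, only, known or untested is meant among the compounds shown, and "the series" means these compounds.

Measured so far:
Compound 1 `CC(=O)NCCCOc1cccc2c1OCCO2` — 631 nM
Compound 2 `CCCNC(=O)NCCOc1cccc2c1OCCO2` — 7940 nM

Both compounds share the same core and were tested in an assay (Ovis aries) for binding affinity to melatonin receptor type 1A (Homo sapiens); a lower number here means a stronger inhibitor, a higher number a weaker inhibitor. Compound 2 holds the higher of the two numbers, and the gap to compound 1 lies beyond the usual scatter, so compound 2 is the weaker binder of the pair. The two differ in more than one place, so only their values can be compared, not a single change.

Compound 3 `CC(=O)NCCOc1cccc2c1OCCO2` has not been measured. It keeps the chain and core of compound 2 and changes only the group on the carbonyl: methyl in place of propylamino on a carbonyl carbon. Compound 3 thus carries the same acetyl group that compound 1 carries, on the shorter chain of compound 2.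

Going by the values given here, no measured pair isolates this change. The expectation for compound 3 in this assay is a lower number than compound 2, a step beyond the scatter, with compound 1 as the only anchor that an acetyl-bearing compound can bind well. Compound 3 is estimated at 800 nM, within a range from 150 nM to 3500 nM, which would mean a step of a 9.9-fold lower number from compound 2 to compound 3 (1.00 log units; beyond the scatter).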

Compound 3, half-maximal inhibitory concentration: 3160 nM
Estimate against measurement, compound 3: 4.0-fold (0.60 log units) below; the range from low to high includes it.
By their numbers in this assay, from the lowest: compound 1; then compound 3; then compound 2.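

In this assay, methyl in place of propylamino on a carbonyl carbon gives a 2.5-fold lower number from compound 2 to compound 3 (0.40 log units; beyond the scatter) on this shorter chain, so the acetyl end gives the lower number of the two here, although the step is modest. The acetyl group alone does not bring the number down to that of compound 1: acetamido in place of acetamidomethyl on a saturated chain carbon, two bonds along the chain from an oxygen on an aromatic ring, gives a 5.0-fold higher number from compound 1 to compound 3 (0.70 log units; beyond the scatter) even though the acetyl group stays the same. The chain therefore matters as well as the group on the carbonyl, but no available evidence says what lies behind either step.

On these data alone, it remains open whether propylamino on the longer chain of compound 1 would give the same step as it does on the shorter one, or whether the two changes act independently. Also open, as far as these compounds go, is how a chain longer than that of compound 1, or an ethyl or cyclopropyl group on the carbonyl, would fare in this assay against these three compounds.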